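Phenyl to 1-benzofuran-2-yl on compound 3

A few compounds are considered here, and "the series" means these few. Any claim that something is new, unique, unknown or untested is made for them only; others in the source may bear on it.

Measured in a functional assay on CEM-DNR-bulk cells (Homo sapiens), read by MTT assay, with a stated time of 72 h; on this read-out higher numbers stand for weaker inhibition and lower numbers for stronger inhibition:
Compound 1 `COc1ncnc2c1c(-c1cc3ccccc3o1)cn2[C@@H]1O[C@H](CO)[C@@H](O)[C@H]1O` gives 10800 nM
Compound 2 `COc1nc(N)nc2c1c(-c1ccsc1)cn2[C@@H]1O[C@H](CO)[C@@H](O)[C@H]1O` gives > 20000 nM (a limit)
Compound 3 `COc1nc(N)nc2c1c(-c1ccccc1)cn2[C@@H]1O[C@H](CO)[C@@H](O)[C@H]1O` gives > 20000 nM (a limit)

Compound 3 has no exact number and stands at the limit of > 20000 nM in this assay, at which 2 of the 3 values shown sit, as a limit only. Compound 4 `COc1nc(N)nc2c1c(-c1cc3ccccc3o1)cn2[C@@H]1O[C@H](CO)[C@@H](O)[C@H]1O` differs from it at one place, where 1-benzofuran-2-yl takes the place of phenyl: 1-benzofuran-2-yl in place of phenyl on an aromatic carbon on an aromatic carbon. Among the measured compounds shown here, the only measured step is a step that the two limits leave unreadable from compound 2 to compound 3 and offers no size to carry over. Compound 1 carries the same 1-benzofuran-2-yl group on a different core and gives 10800 nM as a real number. A modest shift toward stronger inhibition in this assay is therefore expected, namely an at least 1.4-fold lower number from compound 3 to compound 4 (0.15 log units; that floor lies within the scatter) as an estimate, though a result at the limit remains possible. For compound 4 the estimated value is 14000 nM with 6000 nM to 25000 nM as the expected range.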

Compound 4, half-maximal inhibitory concentration: 16700 nM
Beside the measured number, compound 4's estimate is 1.2-fold (0.08 log units) below it; the range from low to high includes it.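

In this assay compound 4 is the only compound shown with the amino group on the core that gives a real number, which bounds the change as an at least 1.1-fold lower number from compound 3 to compound 4 (0.07 log units; that floor lies within the scatter) and as an at least 1.1-fold lower number from compound 2 to compound 4 (0.07 log units; that floor lies within the scatter). Both floors lie within the scatter, so 1-benzofuran-2-yl cannot yet be said to beat phenyl or thiophen-3-yl at this position. With 1-benzofuran-2-yl held fixed, the amino group gives a 1.5-fold higher number from compound 1 to compound 4 (0.19 log units; within the scatter), so amino in place of hydrogen makes no clear difference here.

On these data alone, the step between compound 2 and compound 3 cannot be read, and the true size of the other two stays open: the limit of > 20000 nM in this assay, at which 2 of the 4 values shown sit. Whether an amine or a carboxylic acid carried on this aromatic carbon would move the number beyond the scatter also stays open.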